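Pyridyl terminus variation in an acrylamide series on Ramos cells

The source may hold more compounds than are shown below. What is called first, only, known or untested is meant among the compounds shown, and "the series" means these compounds.

The series shares one acrylamide-bearing core and varies the group on the far aryl ring. Compound 1 `C=CC(=O)Nc1cccc(Nc2ncnc(Nc3ccc(C(=O)Nc4ccc(C)cn4)cc3)n2)c1` carries an amide-linked methylpyridine. Compound 2 `C=CC(=O)Nc1cccc(Nc2ncnc(Nc3ccc(-c4ccc(C)nc4)cc3)n2)c1` and compound 3 `C=CC(=O)Nc1cccc(Nc2ncnc(Nc3ccc(-c4ccc(OC)nc4)cc3)n2)c1` carry the pyridine directly attached, with a methyl and a methoxy group.

In a functional assay on Ramos cells (Homo sapiens) for antiproliferative activity, read by CCK-8 assay, with a stated time of 24 h (a lower number here means a stronger inhibitor, a higher number a weaker inhibitor), compound 1 gives only a limit, > 100000 nM, and not a number. For compound 2 this assay records "not determined" (no result reported). Compound 3 likewise stands with "not determined" (no result reported) in this assay, so no single number is known for it. Of the three entries in the set, only compound 1 yields a limit while the other two are without a number, as summarized by the limit of > 100000 nM in this assay, at which 1 of the 3 values shown sits.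

Compound 4 `C=CC(=O)Nc1cccc(Nc2ncnc(Nc3ccc(-c4cccnc4)cc3)n2)c1` is the next member and differs from compound 3 by hydrogen in place of methoxy on an aromatic carbon. Within the data shown here, no measured pair in the set isolates this change, so its size and direction in this assay cannot be read from the data; a step no larger than the usual scatter, in either direction, is the neutral expectation.

Given that the only numerical information in the set is the limit shown for compound 1, compound 4 is estimated at 30000 nM in this assay, expected to lie between 3000 nM and 100000 nM.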

Compound 4, half-maximal inhibitory concentration: > 100000 nM
Compound 4 ended at the assay's limit; the forecaster's own chance of this, stated with the estimate: 40%; middle value at least 3.3-fold (0.52 log units) away from the limit.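

Compound 1 and compound 4 each give a limit and not a number, so no step between them can be read: the limit of > 100000 nM in this assay, at which 2 of the 4 values shown sit.

The compounds shown leave open whether any variation of the far group gives a single number in this assay, and what 6-methoxypyridin-3-yl in place of pyridin-3-yl does there.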